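Adding Bromo to Compound 2: A Small Expected Step

The source may report more compounds than this note shows. Statements on the series, on what has been measured and on what is new or still open speak of the compounds shown alone.

Compound 1 (`COc1cc(OC)c2sc(-c3ccc(N/C=C\C(=O)c4cc(OC)c(OC)c(OC)c4Br)c(C)c3)nc2c1`) gives 16000 nM 
Compound 2 (`COc1cc(OC)c2sc(-c3ccc(N/C=C\C(=O)c4cc(OC)c(OC)c(OC)c4)cc3)nc2c1`) gives 26800 nM 

In a functional assay on MIA PaCa-2 cells (Homo sapiens) for antiproliferative activity, read by sulforhodamine B assay, with a stated time of 48 h (a lower number here means a stronger inhibitor, a higher number a weaker inhibitor), compound 2 (26800 nM) stands level with compound 1 (16000 nM), the two values lying within the usual scatter of each other. Compound 3 (`COc1cc(OC)c2sc(-c3ccc(N/C=C\C(=O)c4cc(OC)c(OC)c(OC)c4Br)cc3)nc2c1`) is compound 2 with bromo in place of hydrogen on an aromatic carbon. Going by the values given here, no measured pair isolates this change, so there is no direct guide to its size. In this assay the expectation is a step no larger than the scatter, if anything toward a lower number. This rests on compound 1 (16000 nM), which also carries bromo and shows a value of the same order. The step expected a 1.5-fold lower number from compound 2 to compound 3 (0.17 log units; within the scatter) is therefore small. For compound 3 the estimated value is 18000 nM (expected range 7000 nM to 40000 nM).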

Compound 3, half-maximal inhibitory concentration: 19000 nM
For compound 3 the middle estimate is 1.1-fold (0.02 log units) below the measured one, and the stated range covers the measured number.
By their numbers in this assay, from the lowest: compounds 1, 3 and 2 (each within the scatter of the next).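

In this assay the change can now be read directly: a 1.4-fold lower number from compound 2 to compound 3 (0.15 log units; within the scatter) shows that bromo in place of hydrogen on this aromatic carbon, ortho to a large group, leaves compound 3 level with compound 2. The second pair, a 1.2-fold higher number from compound 1 to compound 3 (0.07 log units; within the scatter) for hydrogen in place of methyl on an aromatic carbon, also shows no separation, so compound 3 stands level with compound 1 whether or not that methyl is present. Nothing available here accounts for either result.

What the compounds shown leave open is whether another group on the same aromatic carbon, such as an amine or a carboxylic acid, would move the number beyond the scatter. As far as these compounds go, it is also open whether bromo would behave the same way on another carbon of this ring.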